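A Hydroxy on the Propyl Chain of Compound 3

The source may report more compounds than this note shows. Statements on the series, on what has been measured and on what is new or still open speak of the compounds shown alone.

In a functional assay on HCT-116 cells (Homo sapiens) for inhibition, read by resazurin assay, with a stated time of 48 h (a lower number here means a stronger inhibitor, a higher number a weaker inhibitor), compound 3 `CCCNc1nc(/C=C/c2cc(OC)c(OC)c(OC)c2)cc(/C=C/c2cc(OC)c(OC)c(OC)c2)n1` gives 21900 nM. It stands within the scatter of compound 2 `CCCNc1nc(/C=C/c2ccc(OC)c(OC)c2)cc(/C=C/c2ccc(OC)c(OC)c2)n1`, which gives 28000 nM. Compound 1 `CCNc1nc(/C=C/c2ccc(OC)c(OC)c2)cc(/C=C/c2ccc(OC)c(OC)c2)n1` gives 46400 nM, a number from which compound 3 stands apart by more than the scatter. Compound 4 `COc1cc(/C=C/c2cc(/C=C/c3cc(OC)c(OC)c(OC)c3)nc(NCCCO)n2)cc(OC)c1OC` differs from compound 3 by hydroxy in place of hydrogen on a saturated chain carbon, three bonds along the chain from a nitrogen on an aromatic ring. Among the measured compounds shown here, the only measured step touching this chain, a 1.7-fold lower number from compound 1 to compound 2 (0.22 log units; within the scatter), concerns a lengthening of the chain rather than a hydroxy, so it bears on the new change only loosely; what it does show is that alterations on this chain have so far moved the number little. The expected step is therefore a 1.1-fold lower number from compound 3 to compound 4 (0.04 log units; within the scatter), nothing beyond the scatter. Compound 4 is estimated at 20000 nM, between 8000 nM and 50000 nM.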

Compound 4, half-maximal inhibitory concentration: 7400 nM
Compound 4: the middle estimate sits 2.7-fold (0.43 log units) above what was measured; the whole stated range lies above it.
By their numbers in this assay, from the lowest: compound 4; then compounds 3, 2 and 1 (each within the scatter of the next, the first and the last beyond it).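

Propyl to 3-hydroxypropyl is the first change on this chain to go beyond the scatter in this assay, with a 3.0-fold lower number from compound 3 to compound 4 (0.47 log units; beyond the scatter), whereas the lengthening of the chain gave only a 1.7-fold lower number from compound 1 to compound 2 (0.22 log units; within the scatter). This place, on a saturated chain carbon, three bonds along the chain from a nitrogen on an aromatic ring, therefore responds to the hydroxy. Nothing given here accounts for the step. As far as these compounds go, whether an amine or a carboxylic acid in place of the hydroxy would give a similar step remains open. So does the effect of a longer chain carrying the hydroxy.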